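A few compounds are considered here, and "the series" means these few. Any claim that something is new, unique, unknown or untested is made for them only; others in the source may bear on it.

Three compounds share one core and differ only in the chain that hangs from the oxygen on the aromatic ring. Compound 1 `CCc1cc(C(C)=O)c(O)cc1OCCCCC#N` gives 57% in an assay on isolated protein for binding affinity to leukotriene B4 receptor 1 (Homo sapiens), tested at 1 uM; a higher number here means more inhibition at the concentration tested (going by the name of the read-out), a lower number less inhibition. Compound 2 `CCc1cc(C(C)=O)c(O)cc1OCCCCCCC#N` gives 73%, and compound 3 `CCc1cc(C(C)=O)c(O)cc1OCCCC(C)(C)C#N` gives 46%. Compound 3 thus stands lowest of the three: its nearest neighbour is compound 1 and its furthest is compound 2, and both gaps lie beyond the usual scatter.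

Compound 4 `CCc1cc(C(C)=O)c(O)cc1OCCCCC(C)(C)C#N` has not yet been measured. Its change from compound 3 is 2-cyano-2-methylpropyl in place of 1-cyano-1-methylethyl on a saturated chain carbon, three bonds along the chain from an oxygen on an aromatic ring. The two methyl groups and the nitrile are kept, while the chain grows longer.

The measured steps bear on this only in part. Lengthening the chain gave a number 16 percentage points higher from compound 1 to compound 2 (beyond the scatter). Adding the two methyl groups gave a number 11 percentage points lower from compound 1 to compound 3 (beyond the scatter) and a number 27 percentage points lower from compound 2 to compound 3 (beyond the scatter), so the two steps that introduced branching lowered the number while the one that added length raised it. Compound 4 keeps the branching and adds length, so a small rise is expected, of about a number 8 percentage points higher from compound 3 to compound 4 (within the scatter), which may not clear the scatter. Compound 4 is therefore estimated at 54% in this assay, with a likely range from 40% to 68%.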

Compound 4, a percentage reported as inhibition, at one concentration (the size of the read-out at that concentration, not a potency): 30%
For compound 4 the middle estimate is 24 percentage points above the measured one; the whole stated range lies above it.
By their numbers in this assay, from the lowest: compound 4; then compound 3; then compound 1; then compound 2.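

In this assay the effect of added length turns out to depend on the two methyl groups: lengthening the unbranched chain of compound 1 raised the number, but the same kind of change on the branched chain gives a number 16 percentage points lower from compound 3 to compound 4 (beyond the scatter) at this position. The branched 2-cyano-2-methylpropyl compound also falls clearly short of both unbranched chains, with a number 27 percentage points lower from compound 1 to compound 4 (beyond the scatter) and the largest step in the set, a number 43 percentage points lower from compound 2 to compound 4 (beyond the scatter), which leaves compound 4 lowest of the four. The effects of length and branching therefore cannot simply be added together in this small set, and nothing available here explains why the direction reverses.

With only two chain lengths shown for each chain type, it remains open whether a still longer branched chain, such as 3-cyano-3-methylbutyl, would lower the number further or bring it back up. Also open, from the compounds shown here alone, is how a chain carrying a single methyl group would behave, and whether a carboxylic acid in place of the nitrile would keep the same reversal.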